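Cyano-aminotetrahydroquinoline sulfonamides: cytotoxicity on Ehrlich cells

A few compounds are considered here, and "the series" means these few. Any claim that something is new, unique, unknown or untested is made for them only; others in the source may bear on it.

Measured so far:
compound 1 `N#CC1=C(N)N(c2ccc(S(N)(=O)=O)cc2)C2=C(CCCC2)C1c1ccc(O)cc1` — 42%
compound 2 `N#CC1=C(N)N(c2ccc(S(N)(=O)=O)cc2)C2=C(CCCC2)C1c1cccc([N+](=O)[O-])c1` — 1%
compound 3 `N#CC1=C(N)N(c2ccc(S(N)(=O)=O)cc2)C2=C(CCCC2)C1c1ccc([N+](=O)[O-])cc1` — 5%

In a functional assay on Ehrlich cells (Mus musculus) for cytotoxicity, read by trypan blue exclusion, with a stated time of 2 h, tested at 25 ug/mL (on this read-out higher numbers stand for a stronger effect at the one concentration tested and lower numbers for a weaker effect), compound 1 gives 42%, compound 2 gives 1% and compound 3 gives 5%. Compound 3 stands second highest of the three numbers; its nearest neighbour is compound 2, within the scatter, while compound 1 lies far above it, beyond the scatter.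

The next compound, compound 4 `N#CC1=C(N)N(c2ccc(S(N)(=O)=O)cc2)C2=C(CCCC2)C1c1ccc(Cl)c(Cl)c1`, differs from compound 3 in one place: 3,4-dichlorophenyl in place of 4-nitrophenyl on a saturated ring carbon.

Going by the values given here, two measured steps touch this position. Moving the nitro group between the two ring positions changed little, a number 4 percentage points higher from compound 2 to compound 3 (within the scatter). Exchanging hydroxy for nitro on that aromatic carbon cost a great deal, a number 37 percentage points lower from compound 1 to compound 3 (beyond the scatter). Among the compounds with values here, no measured step shows chlorine on this ring, so the direction of the change to 3,4-dichlorophenyl is not fixed by the series; both nitro compounds sit low, and the only high number belongs to the hydroxy compound 1.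

Compound 4 is therefore expected near the nitro pair, with a wide range: estimated 12% (0% to 40%), a step of a number 7 percentage points higher from compound 3 to compound 4 (within the scatter) that is expected to stay within the scatter.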

Compound 4, a percentage reported as activity, at one concentration (the size of the read-out at that concentration, not a potency): 40%
For compound 4 the middle estimate is 28 percentage points below the measured one; the range from low to high includes it.
By their numbers in this assay, from the lowest: compounds 2 and 3 (each within the scatter of the next); then compounds 4 and 1 (each within the scatter of the next).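

In this assay the low numbers do not belong to this saturated ring carbon as such: with a number 35 percentage points higher from compound 3 to compound 4 (beyond the scatter) and a number 39 percentage points higher from compound 2 to compound 4 (beyond the scatter) they stay confined to the two nitrophenyl compounds among those shown. A high number also does not depend on the 4-hydroxyphenyl group, since a number 2 percentage points lower from compound 1 to compound 4 (within the scatter) places the 3,4-dichlorophenyl group level with it, although the entering group counts no hydrogen-bond donors or acceptors. Nothing measured here accounts for these steps.

Open, on these data alone, is whether a single chlorine on this aromatic ring reads like the pair of chlorines in compound 4, and at which ring position it would need to stand. Also open, as far as these compounds go, is how a methoxy group, an amine or a carboxylic acid on the same ring would read against the high and low numbers seen so far.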